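A few compounds are considered here, and "the series" means these few. Any claim that something is new, unique, unknown or untested is made for them only; others in the source may bear on it.

Measured compounds:

compound 1, `ClCc1ccc(Cn2cnc3c(Cl)ncnc32)cc1`: 33900 nM
compound 2, `ClCc1cccc(Cn2cnc3c(Cl)ncnc32)c1`: 3380 nM

In a functional assay on UACC-62 cells (Homo sapiens) for cytotoxicity, read by sulforhodamine B assay, with a stated time of 48 h (a higher number here means a weaker inhibitor of growth, a lower number a stronger inhibitor of growth), compound 1 gives 33900 nM, the highest of the two numbers in hand. Among the compounds with values here, its nearest neighbour is compound 2, which in this assay gives 3380 nM, a lower number by a margin beyond the scatter; the two differ in where the chloromethyl group sits on the benzyl ring, and no step is counted for that pair.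

Compound 3, `ClCc1ccc(Cn2cnc3c(Cl)nc(Cl)nc32)cc1`, keeps the benzyl part of compound 1 and changes the shared core: chloro in place of hydrogen on an aromatic carbon. Within the data shown here, no measured pair shows this change, so nothing in hand sets its direction. Given only the common core, the step from compound 1 is expected to be small: a 1.7-fold lower number from compound 1 to compound 3 (0.23 log units; within the scatter), likely within the scatter, with a slight lean to a lower number. Compound 3 is estimated at 20000 nM, within 5000 nM to 80000 nM.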

Compound 3, concentration for total growth inhibition: 4370 nM
The estimate for compound 3 lay 4.6-fold (0.66 log units) above the measured number, outside the stated range (below it).
By their numbers in this assay, from the lowest: compounds 2 and 3 (each within the scatter of the next); then compound 1.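

In this assay, chloro in place of hydrogen on an aromatic carbon, between two ring nitrogen atoms, gives a 7.8-fold lower number from compound 1 to compound 3 (0.89 log units; beyond the scatter) and is a step beyond the scatter. Within the data shown here, this is the first reading of a change on the shared core, as compounds 1 and 2 differ only on the benzyl ring, and it shows that this carbon of the core is not indifferent to substitution when the benzyl part of compound 1 is held fixed. Nothing at hand gives a measured reason for the size of this step.

On these data alone, whether the same change carries over to the benzyl part of compound 2 remains open. So does whether the step belongs to chloro itself or would also appear with an amine, a methyl or a methoxy group on this carbon.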